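This account rests on a few compounds, and the source may have more. Where it says the series, first, only, none or still open, it means among the compounds named here.

In a functional assay on HT-29 cells (Homo sapiens) for antiproliferative activity, read by MTT assay, with a stated time of 96 h (a higher number here means a weaker inhibitor, a lower number a stronger inhibitor), compound 1 (`O=C1NNC(=O)C2(CSC3=C2C(=O)c2ncccc2C3=O)N1`) gives 1580 nM; 1600 nM; 1600 nM (3 entries) and compound 2 (`CCCCCc1ccc(N2C(=O)NC3(CSC4=C3C(=O)c3ncccc3C4=O)C2=O)cc1`) gives 250 nM as the lower of the two values shown. Compound 3 (`CC(C)(C)c1ccc(N2C(=O)NC3(CSC4=C3C(=O)c3ncccc3C4=O)C2=O)cc1`) carries tert-butyl in place of pentyl on an aromatic carbon, para to a large group (tert-butyl in place of pentyl on an aromatic carbon). Among the compounds with values here, no measured step covers this change, so in this assay no shift beyond the scatter is expected, in either direction. The estimated change (a 1.1-fold higher number from compound 2 to compound 3 (0.05 log units; within the scatter)) stays within that scatter. For compound 3 the expected value is estimated at 280 nM (range 100 nM to 800 nM).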

Compound 3, half-maximal inhibitory concentration: 150 nM
Estimate against measurement, compound 3: 1.9-fold (0.27 log units) above; measured number inside the range.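

At this position on the six-membered aromatic ring, para to a large group, tert-butyl in place of pentyl gives, in this assay, a 1.7-fold lower number from compound 2 to compound 3 (0.22 log units; within the scatter). Within the data shown here, this is the first step read at this position, and it does not separate the two chains, so swapping pentyl for tert-butyl has no effect that can be told from the scatter. Repeat readings in this assay agree closely for the one compound that has them: the several entries of compound 1 in this assay, 1580 nM; 1600 nM; 1600 nM (3 entries)

As far as these compounds go, an amine, a carboxylic acid or a longer chain at this position remains open, as does a plain hydrogen there.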